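The source may report more compounds than this note shows. Statements on the series, on what has been measured and on what is new or still open speak of the compounds shown alone.

Compound 1, `CN(C)CCCOc1ccc(CN2CC[C@H](NC(=O)c3cc(Cl)cc(Cl)c3)C2)cc1`: 2000 nM
Compound 2, `CN(C)CCCOc1ccc(CN2CC[C@H](NC(=O)c3ccccc3)C2)cc1`: 2510 nM
Compound 3, `CN(C)CCCOc1ccc(CN2CC[C@H](NC(=O)c3ccncc3)C2)cc1`: < 10000 nM

In an assay on HEK293 cells for binding affinity to Urotensin-2 receptor (Homo sapiens), read by radioligand binding (a higher number here means a weaker inhibitor, a lower number a stronger inhibitor), compound 1 gives 2000 nM and compound 2 gives 2510 nM; the step of a 1.3-fold higher number from compound 1 to compound 2 (0.10 log units; within the scatter) shows that exchanging the two aryl groups on the carbonyl carbon changes little. For compound 3 this assay reports only a limit, < 10000 nM. Because of the limit of < 10000 nM in this assay, at which 1 of the 3 values shown sits, the steps a step that the limit leaves unreadable from compound 1 to compound 3 and a step that the limit leaves unreadable from compound 2 to compound 3 cannot be sized, so where compound 3 stands relative to compounds 1 and 2 is not known from these numbers.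

Compound 4, `CC(=O)N[C@H]1CCN(Cc2ccc(OCCCN(C)C)cc2)C1`, carries the change (methyl in place of pyridin-4-yl on a carbonyl carbon). For the measured compounds named here, no measured step covers a change of this kind; the only readable step, a 1.3-fold higher number from compound 1 to compound 2 (0.10 log units; within the scatter), concerns an exchange between two aromatic groups and is within the scatter, while both steps leading to compound 3 are unreadable. Without a readable comparison, and with the aromatic group removed entirely, compound 4 is expected to sit at or beyond the limit, estimated at 10000 nM (range 3000 nM to 30000 nM), the expected step being a number no lower from compound 3 to compound 4 (the limit leaves the size open).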

Compound 4, inhibition constant: < 10000 nM
Compound 4 ended at the assay's limit; the forecaster's own chance of this, stated with the estimate: 65%; the middle value sits exactly at the limit.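

Compound 4, like compound 3, gives only a limit in this assay, so none of the steps from compounds 1, 2 and 3 to compound 4 can be read: the limit of < 10000 nM in this assay, at which 2 of the 4 values shown sit.

The compounds shown leave open how far compounds 3 and 4 actually stand from compounds 1 and 2, and from each other.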